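Swapping a Pyridinylmethyl for a Pyrazinyl on a Piperazine

A few compounds are considered here, and "the series" means these few. Any claim that something is new, unique, unknown or untested is made for them only; others in the source may bear on it.

Of the compounds shown here, three that share one core have been tested in a functional assay on HeLa cells (Homo sapiens) for antiproliferative activity, read by CCK-8 assay, with a stated time of 72 h, tested at 8 uM; on this read-out higher numbers stand for a stronger effect at the one concentration tested and lower numbers for a weaker effect. Compound 1 `Nc1ccccc1NC(=O)c1ccc(CSC(=S)N2CCN(Cc3ccccn3)CC2)cc1` carries a (pyridin-2-yl)methyl group on an amine nitrogen in a ring and gives 61.4%. Compound 2 `Nc1ccccc1NC(=O)c1ccc(CSC(=S)N2CCN(C(c3ccccc3)c3ccccc3)CC2)cc1`, which bears a diphenylmethyl group on the same kind of nitrogen, gives 13.8%, a number that lies below compound 1 by more than the usual scatter. Compound 3 `CC1CCCCN1C(=S)SCc1ccc(C(=O)Nc2ccccc2N)cc1`, built around a different ring at this end of the molecule, gives 76.3%, a number above compound 1 by more than the scatter. Among these three numbers compound 1 therefore stands second highest, with compound 3 as its nearest neighbour above it and compound 2 as its furthest, well below it.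

Compound 4 `Nc1ccccc1NC(=O)c1ccc(CSC(=S)N2CCN(c3cnccn3)CC2)cc1` follows from compound 1 by a single change: pyrazin-2-yl in place of (pyridin-2-yl)methyl on an amine nitrogen in a ring. The entering group is smaller and brings one more hydrogen-bond acceptor than the group it replaces. Going by the values given here, no pair among the measured compounds shows this kind of exchange, so there is no direct precedent for its effect. In this assay the step from compound 1 to compound 4 is expected to be a modest one downward, close to the edge of the scatter: a number 9.4 percentage points lower from compound 1 to compound 4 (within the scatter). Compound 4 is accordingly estimated to give 52%, within a range from 28% to 74%.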

Compound 4, a percentage reported as inhibition, at one concentration (the size of the read-out at that concentration, not a potency): 76.9%
Estimate against measurement, compound 4: 24.9 percentage points below; measured number outside the range, above it.
By their numbers in this assay, from the lowest: compound 2; then compound 1; then compounds 3 and 4 (each within the scatter of the next).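

In this assay, the amine nitrogen in a ring proves open to a direct exchange of its aromatic group, and the step is upward: a number 15.5 percentage points higher from compound 1 to compound 4 (beyond the scatter). Pyrazin-2-yl has 6 heavy atoms and 2 hydrogen-bond acceptors against 7 and 1 for (pyridin-2-yl)methyl, so at this position a slightly smaller group with a second ring nitrogen gives a stronger effect at the one concentration tested, not a lower one. No measurement here accounts for this gain in terms of any property of the two groups.

The exchange removes the methyl link and adds a ring nitrogen in one move, so the compounds shown leave open which of the two matters, and a pyridin-2-yl group or a (pyrazin-2-yl)methyl group on the same nitrogen would pull these two changes apart. Also open, from the compounds shown here alone, is whether the step reflects a true difference in potency, since each number comes from a single concentration and a full concentration series would be needed to settle that.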